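A few compounds are considered here, and "the series" means these few. Any claim that something is new, unique, unknown or untested is made for them only; others in the source may bear on it.

Working notes on the series. In a functional assay on MCF7 cells (Homo sapiens) for inhibition, read by sulforhodamine B assay (a higher number here means that more compound is tolerated, a lower number that less compound is tolerated), compound 1 `CC1(C)CCC[C@]2(C)[C@@H](/C=C/C3=CCOC3=O)C(C=O)=CC(=O)[C@@H]12` gives only a limit, > 100000 nM, and not a number; (the limit of > 100000 nM in this assay, at which 1 of the 3 values shown sits). Compound 2 `CC1(C)CCC[C@]2(C)[C@@H](/C=C/C3=CC(=O)OC3)C(CO)=C(O)C(=O)[C@@H]12` gives 15400 nM in this assay. Compound 3 `C=C1CC[C@H]2C(C)(C)CCC[C@]2(C)[C@H]1C/C=C1/CC(O)OC1=O` gives 21900 nM in this assay. The two measured numbers sit within the usual scatter of each other, so nothing separates compound 2 from compound 3 on these data. Compound 1 stands apart from both only in that it reached the limit of this assay where the other two did not.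

The unmeasured compound 4 `CC1=CC(=O)[C@H]2C(C)(C)CCC[C@]2(C)[C@H]1/C=C/C1=CCOC1=O` is compound 1 with a single change: methyl in place of formyl on a double-bonded ring carbon. Among the compounds with values here, no step between two measured compounds touches the same position, so there is no measured step to lean on for the direction or size of this change.

Given that compound 1 gives > 100000 nM as a limit only, the expected step of an at least 1.4-fold lower number from compound 1 to compound 4 (0.15 log units; that floor lies within the scatter) is small and is taken as no change beyond the scatter. Compound 4 is therefore estimated at 70000 nM in this assay, within a range of 15000 nM to 300000 nM, with a fair chance that the assay again reports only a limit.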

Compound 4, concentration lethal to 50% of the cells: 19800 nM
Estimate against measurement, compound 4: 3.5-fold (0.55 log units) above; measured number inside the range.
By their numbers in this assay, from the lowest: compounds 2, 4 and 3 (each within the scatter of the next). At a limit, above all of these: compound 1.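

In this assay, within the data shown here, methyl in place of formyl on the double-bonded ring carbon gives an at least 5.0-fold lower number from compound 1 to compound 4 (0.70 log units; beyond the scatter), the only measured step, showing that this one exchange, with the rest of the core of compound 1 unchanged, is enough to move the read-out beyond the scatter. Compound 1 gives > 100000 nM, which is a limit of the assay and not a number. The size of the step therefore remains a floor, and the true gap may be wider, because one end of it rests on that limit: the limit of > 100000 nM in this assay, at which 1 of the 4 values shown sits.

With a single exchange at this position, the data cannot separate the loss of the formyl from the gain of the methyl, and a hydrogen, a hydroxymethyl, a carboxylic acid or an aminomethyl group on the same ring carbon would be needed to tell the two apart. Also open, as far as these compounds go, is whether the same exchange would run in the same direction on the cores of compound 2 and compound 3, which differ from compound 1 in more than one place.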